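The source may hold more compounds than are shown below. What is called first, only, known or untested is meant among the compounds shown, and "the series" means these compounds.

Compound 2 `Cn1c(-c2ccc(NC(=O)CSC3=NCCS3)cc2)nc(-c2ccccc2)c1-c1ccccc1` stands at one end of the two numbers shown: in a functional assay on MCF7 cells (Homo sapiens) for cytotoxicity, read by MTT assay, with a stated time of 24 h, tested at 0.64 ug/mL (on this read-out higher numbers stand for a stronger effect at the one concentration tested and lower numbers for a weaker effect), compound 2 gives 10.3%, while compound 1 `Cn1c(-c2ccc(NC(=O)CSc3nc4ccccc4o3)cc2)nc(-c2ccccc2)c1-c1ccccc1` gives 18.7%, and the step of a number 8.4 percentage points lower from compound 1 to compound 2 (within the scatter) is within the scatter. Compound 3 `CN1CCN(CC(=O)Nc2ccc(-c3nc(-c4ccccc4)c(-c4ccccc4)n3C)cc2)CC1` differs from compound 2 by a group of 7 heavy atoms (5 carbon, 2 nitrogen; one six-membered non-aromatic ring with 2 hetero atoms) in place of a group of 6 heavy atoms (3 carbon, 1 nitrogen, 2 sulfur; one five-membered non-aromatic ring with 2 hetero atoms), on a saturated chain carbon bound to a carbonyl carbon. Among the measured compounds shown here, the only step measured, that from compound 1 to compound 2, altered a group on a sulfur and stayed within the scatter, so for compound 3 a step of a number 1.7 percentage points higher from compound 2 to compound 3 (within the scatter) is expected, none beyond the scatter. Compound 3 is therefore estimated at 12%, between 0% and 30%.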

Compound 3, a percentage reported as activity, at one concentration (the size of the read-out at that concentration, not a potency): 1.1%
Beside the measured number, compound 3's estimate is 10.9 percentage points above it; measured number inside the range.
By their numbers in this assay, from the lowest: compounds 3, 2 and 1 (each within the scatter of the next, the first and the last beyond it).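

With 4-methylpiperazin-1-yl on the saturated chain carbon bound to a carbonyl carbon, this assay shows its first step beyond the scatter, a number 17.6 percentage points lower from compound 1 to compound 3 (beyond the scatter) against (1,3-benzoxazol-2-yl)sulfanyl at that place. Against the group of compound 2, the same change gives a number 9.2 percentage points lower from compound 2 to compound 3 (within the scatter) and so does not separate the two compounds. Nothing available here bears on this result.

Going by these compounds, it remains open whether another amine at this place, such as morpholin-4-yl or dimethylamino, would stand with compound 3. The same question holds for a sulfur-linked group with a six-membered aromatic ring, such as pyridin-2-ylsulfanyl, and compound 1.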